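A few compounds are considered here, and "the series" means these few. Any claim that something is new, unique, unknown or untested is made for them only; others in the source may bear on it.

Measured so far:
- compound 1, `N#Cc1cnc(NCc2cnccc2C(F)(F)F)cc1N[C@H]1CC[C@H](O)CC1`, 350 nM in an assay on isolated protein for inhibition of protein kinase C theta type (Homo sapiens), read by TR-FRET, with a stated time of 2 h; on this read-out higher numbers stand for weaker inhibition and lower numbers for stronger inhibition
- compound 2, `CC(C)(C)Oc1ncncc1CNc1cc(N[C@H]2CC[C@@H](O)CC2)c(C#N)cn1`, 200 nM in this assay

Both compounds share a core carrying a nitrile and two amine-linked substituents. In this assay compound 1 gives 350 nM, and in this assay compound 2 gives 200 nM. The gap between these two values lies within the usual scatter of repeated measurements, so neither compound can be called the stronger or weaker inhibitor on this evidence; compound 1 simply sits alongside compound 2.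

Compound 3, `CC1(C)C[C@H](Nc2cc(NCc3cnccc3C(F)(F)F)ncc2C#N)CC[C@@H]1O`, has not yet been measured. It differs from compound 1 in one place: 4-hydroxy-3,3-dimethylcyclohexyl in place of 4-hydroxycyclohexyl on a nitrogen on an aromatic ring. Among the compounds with values here, no pair of measured compounds shows the effect of this particular change, so there is no precedent to lean on. Because compound 1 gives 350 nM and compound 2 gives 200 nM in this assay, a gap that stays within the scatter, the step from compound 1 to compound 3 is expected to be small as well, with no clear direction beyond the scatter: a 1.2-fold lower number from compound 1 to compound 3 (0.07 log units; within the scatter). Compound 3 is therefore expected to give about 300 nM in this assay, within a range from 100 nM to 900 nM.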

Compound 3, half-maximal inhibitory concentration: 7 nM
For compound 3 the middle estimate is 43-fold (1.63 log units) above the measured one, outside the stated range (below it).
By their numbers in this assay, from the lowest: compound 3; then compounds 2 and 1 (each within the scatter of the next).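

This position, on a nitrogen on an aromatic ring, proves far more sensitive than the two earlier compounds could reveal: in this assay, placing 4-hydroxy-3,3-dimethylcyclohexyl where 4-hydroxycyclohexyl stood gives a 50-fold lower number from compound 1 to compound 3 (1.70 log units; beyond the scatter) and makes this the one difference between compounds shown that clearly exceeds the scatter. The change is small on paper, going from 7 heavy atoms to 9, both of the added atoms being carbon, while the six-membered carbon ring, the hydrogen-bond donor and acceptor counts, the net charge and the number of defined stereocentres stay the same. This single pair shows the size and direction of the step, but no measurement presented here accounts for why so small an addition has so large an effect.

As far as these compounds go, it remains open whether 4-hydroxy-3-methylcyclohexyl, with only one added methyl, would capture part or all of this gain, and whether the hydroxyl could give way to an amine in the dimethyl ring. From the compounds shown here alone, it is equally open whether the same exchange would bring a step of similar size on compound 2, whose other substituent differs from that of compound 1.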